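Chalcone-type pyrazoles: aryl ketone swap, SK-MEL-2 growth

The source may hold more compounds than are shown below. What is called first, only, known or untested is meant among the compounds shown, and "the series" means these compounds.

Measured so far:
compound 1, `COc1cc(-c2cc(/C=C/C(=O)c3ccc(N)cc3)[nH]n2)cc(OC)c1OC`, 104%
compound 2, `COc1ccc(C(=O)/C=C/c2cc(-c3cc(OC)c(OC)c(OC)c3)n[nH]2)cc1OC`, 98%

The two compounds share a core and differ only in the aryl group on the carbonyl carbon. In a functional assay on SK-MEL-2 cells (Homo sapiens) for cytotoxicity, read by sulforhodamine B assay, with a stated time of 48 h, tested at 1 uM (on this read-out higher numbers stand for a weaker effect at the one concentration tested and lower numbers for a stronger effect), compound 1 gives 104% and compound 2 gives 98%. Among the compounds with values here, the one step in hand, a number 6 percentage points lower from compound 1 to compound 2 (within the scatter), is within the scatter, so the exchange of the aryl group on the carbonyl carbon did not move the read-out here. Compound 2 stands at the lower of the two numbers, with compound 1 as its nearest neighbour a short distance above, the gap again within the scatter; no order between them can be read from this.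

Compound 3, `COc1cc(-c2cc(/C=C/C(=O)c3ccc(F)c(F)c3)[nH]n2)cc(OC)c1OC`, is not yet measured. It differs from compound 2 by 3,4-difluorophenyl in place of 3,4-dimethoxyphenyl on a carbonyl carbon. Within the data shown here, the only step that bears on it is the one from compound 1 to compound 2, which was flat. On that basis no change beyond the scatter is expected in this assay: the step of a number 1 percentage points lower from compound 2 to compound 3 (within the scatter) is estimated to be small. For compound 3 the expected value is 97%, in the range 82% to 112%.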

Compound 3, a percentage reported as activity, at one concentration (the size of the read-out at that concentration, not a potency): 94%
The estimate for compound 3 lay 3 percentage points above the measured number; measured number inside the range.
By their numbers in this assay, from the lowest: compounds 3, 2 and 1 (each within the scatter of the next).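

Extending the series on the carbonyl carbon, 3,4-difluorophenyl in place of 3,4-dimethoxyphenyl exchanges a group with 2 hydrogen-bond acceptors for one with 0, yet this assay gives a number 4 percentage points lower from compound 2 to compound 3 (within the scatter). The exchange against the 4-aminophenyl group gives a number 10 percentage points lower from compound 1 to compound 3 (within the scatter), so all three aryl groups now shown at this position fall within the scatter of one another, and the flat result of the first pair holds for a halogenated aryl group as well as for the methoxy-bearing one. Nothing in hand bears on why this position shows no separation among these groups.

The single concentration leaves open whether these three compounds would separate at a higher dose, since a read-out this close to one another says nothing about potency. Also open, as far as these compounds go, is whether a carboxylic acid on the aryl ring, or a longer alkyl chain in place of the aryl group on the carbonyl carbon, would move the read-out beyond the scatter.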